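Nitro-trifluoromethyl series: methyl removal and volume of distribution

A few compounds are considered here, and "the series" means these few. Any claim that something is new, unique, unknown or untested is made for them only; others in the source may bear on it.

Measured compounds:
Compound 1 `O=C(c1sc2c([N+](=O)[O-])cc(C(F)(F)F)cc2[n+]1[O-])N1CCCCC1` — in an ADME assay on the whole organism for pharmacokinetics, with Mus musculus as the target (a higher number here means that more of the compound sits outside the plasma, a lower number that more of the compound stays in the plasma), compound 1 gives "not determined" (no result reported).
Compound 2 `Cc1c(C(F)(F)F)cc2nc(C3=N[C@H](C(=O)N4CCCC4)CO3)sc2c1[N+](=O)[O-]` — in this assay compound 2 gives 3.5 L/kg.

Compound 2 therefore stands alone with the only number shown; compound 1 carries no value there. The next compound, compound 3 `O=C([C@@H]1COC(c2nc3cc(C(F)(F)F)cc([N+](=O)[O-])c3s2)=N1)N1CCCC1`, differs from compound 2 by hydrogen in place of methyl on an aromatic carbon. For the measured compounds named here, no step between measured compounds exists for comparison, so the change from compound 2 to compound 3 is read only as a hydrogen in place of methyl on an aromatic carbon. The expected step is a 1.2-fold lower number from compound 2 to compound 3 (0.07 log units; within the scatter), none beyond the usual scatter. Compound 3 is estimated at 3 L/kg, with a range from 1.5 L/kg to 6 L/kg.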

Compound 3, volume of distribution at steady state: 1.44 L/kg
The estimate for compound 3 lay 2.1-fold (0.32 log units) above the measured number; the measured number lies below the stated range.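

In this assay, the aromatic carbon ortho to a nitro group and ortho to a trifluoromethyl group proves sensitive to a small change: hydrogen in place of methyl gives a 2.4-fold lower number from compound 2 to compound 3 (0.39 log units; beyond the scatter) and goes beyond the scatter, though the step is modest. For the compounds shown here, this single pair is the only readable step so far. Nothing available explains the shift.

Open, from the compounds shown here alone, is how this position responds to groups other than methyl and hydrogen, such as chlorine, methoxy or an amine. Going by these compounds alone, also open is whether the same step holds with an amide other than the one shared by compound 2 and compound 3.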